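Naphthalenyl in Place of Chlorophenyl on the Shared Core

A few compounds are considered here, and "the series" means these few. Any claim that something is new, unique, unknown or untested is made for them only; others in the source may bear on it.

Compound 1 `Nc1nc(-c2ccc(Cl)cc2)cn1/N=C/c1cc2ccccc2nc1Cl` reaches in a functional assay on MDA-MB-231 cells (Homo sapiens) for cytotoxicity, read by MTT assay, with a stated time of 48 h (a lower number here means a stronger inhibitor, a higher number a weaker inhibitor), only a limit, > 50000 nM. Compound 2 `Cc1ccc2nc(Cl)c(/C=N/n3cc(-c4ccc(Cl)cc4)nc3N)cc2c1` gives 35200 nM in this assay, the only number shown so far, and the step of an at least 1.4-fold lower number from compound 1 to compound 2 (0.15 log units; that floor lies within the scatter) rests on that limit (the limit of > 50000 nM in this assay, at which 1 of the 2 values shown sits). Compound 3 `Cc1ccc2nc(Cl)c(/C=N/n3cc(-c4cccc5ccccc45)nc3N)cc2c1` differs from compound 2 by naphthalen-1-yl in place of 4-chlorophenyl on an aromatic carbon. For the measured compounds named here, no measured step touches that aromatic carbon of the five-membered ring, so the data give no direction for the change. Compound 3 is therefore expected at 32000 nM, between 10000 nM and 100000 nM, with a 1.1-fold lower number from compound 2 to compound 3 (0.04 log units; within the scatter) expected to remain within the scatter.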

Compound 3, half-maximal inhibitory concentration: > 50000 nM
Compound 3 ended at the assay's limit; the forecaster's own chance of this, stated with the estimate: 35%; middle value at least 1.5-fold (0.19 log units) from the limit.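

For the aromatic carbon of the five-membered ring, this assay now gives a first step, an at least 1.4-fold higher number from compound 2 to compound 3 (0.15 log units; that floor lies within the scatter). Compound 3 is recorded only as a limit, > 50000 nM. The step therefore sets a floor rather than a size for naphthalen-1-yl in place of 4-chlorophenyl, and the series now rests largely on that limit: the limit of > 50000 nM in this assay, at which 2 of the 3 values shown sit.

As far as these compounds go, it remains open how this carbon would respond to a phenyl without chlorine or to a phenyl bearing an amine. From the compounds shown here alone, it is also open whether any group there would give a number clearly lower than that of compound 2.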